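A few compounds are considered here, and "the series" means these few. Any claim that something is new, unique, unknown or untested is made for them only; others in the source may bear on it.

Measured compounds, the read-out being the concentration for half-maximal growth inhibition:

compound 1, `Cc1ccc(CS/C(=C/c2c[nH]c3ccc(Cl)cc23)C(=O)c2ccc(Cl)cc2)cc1`: 1000 nM
compound 2, `Cc1ccc(CS/C(=C/c2c(O)cc(O)cc2O)C(=O)c2ccc(Cl)cc2)cc1`: 50000 nM
compound 3, `Cc1ccc(CS/C(=C/c2ccc(Cl)cc2)C(=O)c2ccc(Cl)cc2)cc1`: 10000 nM

All three share one core and differ only in the aryl group on the double-bonded chain carbon bound to the other double-bonded chain carbon. In a functional assay on DU-145 cells (Homo sapiens) for inhibition, read by trypan blue exclusion, with a stated time of 96 h (a higher number here means a weaker inhibitor of growth, a lower number a stronger inhibitor of growth), compound 3 stands second highest of the three numbers: a 10-fold higher number from compound 1 to compound 3 (1.00 log units; beyond the scatter) and a 5.0-fold lower number from compound 2 to compound 3 (0.70 log units; beyond the scatter) place it between the other two, closer to compound 2.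

The next compound, compound 4, `Cc1ccc(CS/C(=C/c2cc(C)ccc2C)C(=O)c2ccc(Cl)cc2)cc1`, changes the same position again: 2,5-dimethylphenyl in place of 4-chlorophenyl on a double-bonded chain carbon bound to a double-bonded chain carbon.

For the measured compounds named here, the steps so far bear on it only indirectly. Swaps at this position have shifted the number widely (a 50-fold higher number from compound 1 to compound 2 (1.70 log units; beyond the scatter), a 10-fold higher number from compound 1 to compound 3 (1.00 log units; beyond the scatter), a 5.0-fold lower number from compound 2 to compound 3 (0.70 log units; beyond the scatter)), but each of those brought in a group of a different kind. Here one six-membered all-carbon ring without donors or acceptors replaces another of the same description, so a small step, likely within the scatter of this assay, is expected for compound 4, with a slight lean toward a higher number: a 1.3-fold higher number from compound 3 to compound 4 (0.11 log units; within the scatter).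

Compound 4 is thus estimated at 13000 nM, within 4000 nM to 45000 nM.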

Compound 4, concentration for 50% growth inhibition: 10000 nM
Compound 4: the middle estimate sits 1.3-fold (0.11 log units) above what was measured, within the range that was stated.
By their numbers in this assay, from the lowest: compound 1; then compounds 3 and 4 (each within the scatter of the next); then compound 2.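

In this assay, replacing 4-chlorophenyl with 2,5-dimethylphenyl gives no change at the digits printed from compound 3 to compound 4 (within the scatter), so this position does not separate these two groups, although one carries chlorine and the other two methyl groups. The gaps to the other aryl groups recur with this second ring of carbon only, at a 5.0-fold lower number from compound 2 to compound 4 (0.70 log units; beyond the scatter) and a 10-fold higher number from compound 1 to compound 4 (1.00 log units; beyond the scatter), so the earlier differences from compound 3 are not peculiar to 4-chlorophenyl. No measurement at hand accounts for these numbers.

As far as these compounds go, how a 1H-indol-3-yl group without the chlorine, or a phenyl ring bearing an amine, would stand at this position remains open. Also open, from the compounds shown here alone, is whether the same order of aryl groups would hold with a carboxylic acid in place of the chlorine on the shared 4-chlorophenyl ketone.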